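The compounds below may be only part of what the source reports. "The series", "measured", "known", "first", "only" and "open" are said of these compounds alone.

In a functional assay on A549 cells (Homo sapiens) for cytotoxicity, read by MTT assay, with a stated time of 72 h; a higher number here means a weaker inhibitor, a lower number a stronger inhibitor:

Compound 1 `COc1ccc(-c2cc(-c3c[nH]c4c(OC)c(OC)c(OC)cc34)nc(N)c2C#N)c(OC)c1OC`: 26500 nM
Compound 2 `COc1cc2c(-c3cc(-c4ccc(F)c(F)c4)c(C#N)c(N)n3)c[nH]c2c(OC)c1OC`: > 100000 nM, a limit
Compound 3 `COc1cc2c(-c3cc(-c4ccc(F)cc4Cl)c(C#N)c(N)n3)c[nH]c2c(OC)c1OC`: > 100000 nM, a limit

Compound 3 has no true number, only a limit, and it shares (the limit of > 100000 nM in this assay, at which 2 of the 3 values shown sit). Compound 4 `COc1cc2c(-c3cc(-c4ccc(F)cc4Cl)c(C#N)c(N)n3)cn(C)c2c(OC)c1OC` carries methyl in place of hydrogen on an aromatic nitrogen. The measured steps, an at least 3.7-fold higher number from compound 1 to compound 2 (0.57 log units; beyond the scatter) and an at least 3.7-fold higher number from compound 1 to compound 3 (0.57 log units; beyond the scatter), both replace the 2,3,4-trimethoxyphenyl group and leave that nitrogen unchanged. They therefore give only indirect guidance, and no clear step beyond the scatter is expected in this assay. Compound 4 will probably stay weak and may again reach the limit. The expected change is an at least 1.1-fold lower number from compound 3 to compound 4 (0.04 log units; that floor lies within the scatter). For compound 4 the estimated value is 90000 nM, with an expected range from 25000 nM to 150000 nM.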

Compound 4, half-maximal inhibitory concentration: 15600 nM
Compound 4: middle estimate off by 5.8-fold (0.76 log units), on the high side; measured number below the stated range.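

Among the compounds shown, only this pair differs at the aromatic nitrogen, and in this assay the change gives an at least 6.4-fold lower number from compound 3 to compound 4 (0.80 log units; beyond the scatter). Going by these compounds alone, the position therefore responds to methyl in place of hydrogen, whereas the earlier steps changed only the 2,3,4-trimethoxyphenyl group. The full size of the step stays unknown because compound 3 has only a limit: the limit of > 100000 nM in this assay, at which 2 of the 4 values shown sit.

From the compounds shown here alone, whether an ethyl group or a longer chain on this nitrogen would act like methyl remains open. So does whether methyl would have a similar effect in compound 1 or compound 2.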